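The source may report more compounds than this note shows. Statements on the series, on what has been measured and on what is new or still open speak of the compounds shown alone.

The series rests on a shared core, and the first of its members, compound 1 `C=CC[C@@]12C[C@@H](C(=O)OC)N3[C@@H]1N(C(=N)C31CCCCC1)c1ccccc12`, carries an allyl group and a spiro-fused cyclohexane. In a functional assay on MDA-MB-231 cells (Homo sapiens) for cytotoxicity, read by sulforhodamine B assay, with a stated time of 48 h (a lower number here means that less compound is tolerated, a higher number that more compound is tolerated), compound 1 gives 25700 nM. Compound 2 `COC(=O)[C@@H]1C[C@@]2(CC=C(C)C)c3ccccc3N3C(=N)[C@H](Cc4ccccc4)N1[C@H]32` instead bears a prenyl chain and a benzyl group on the saturated ring carbon. In this assay compound 2 reaches only the limit of the measurement, > 100000 nM. Compound 3 `COC(=O)[C@@H]1C[C@@]2(CC=C(C)C)c3ccccc3N3C(=N)[C@H](c4ccccc4)N1[C@H]32` replaces that benzyl with a phenyl. In this assay compound 3 likewise reaches only the limit, > 100000 nM. The step that the two limits leave unreadable from compound 2 to compound 3 therefore cannot be sized; the only firm point is the limit of > 100000 nM in this assay, at which 2 of the 3 values shown sit, which places compound 3 beside compound 2 rather than beside compound 1.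

Compound 4 `COC(=O)[C@@H]1C[C@@]2(CC=C(C)C)c3ccccc3N3C(=N)[C@H](C(C)(C)C)N1[C@H]32` is the next member; it differs from compound 3 by tert-butyl in place of phenyl on a saturated ring carbon. Among the measured compounds shown here, no measured step bears directly on a tert-butyl at this position, and the one step at this carbon, from benzyl to phenyl, is unreadable between two limits. The expectation is that compound 4 will again sit at the limit of this assay. Compound 4 is thus expected to give 100000 nM, within a range from 40000 nM to 300000 nM. The expected step of a number no higher from compound 3 to compound 4 (the limit leaves the size open) is accordingly estimated to be none beyond the scatter.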

Compound 4, concentration lethal to 50% of the cells: 26200 nM
Beside the measured number, compound 4's estimate is 3.8-fold (0.58 log units) above it; measured number outside the range, below it.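

The result gives the first readable change at this saturated ring carbon, where the earlier step between two limits had shown nothing of the effect of the group. In this assay, tert-butyl gives an at least 3.8-fold lower number from compound 3 to compound 4 (0.58 log units; beyond the scatter), and the same group set against benzyl gives an at least 3.8-fold lower number from compound 2 to compound 4 (0.58 log units; beyond the scatter), so the number at this carbon does respond to the group it carries, and the two groups with an aromatic ring stand apart from tert-butyl, which has no ring. Both steps start from a limit and not from a number, so each gives only a smallest size, and the true drop may be greater: the limit of > 100000 nM in this assay, at which 2 of the 4 values shown sit.

The compounds shown do not separate the loss of the aromatic ring from the other differences between these groups, and they leave the full size of both steps unknown. As far as these compounds go, how a cyclohexyl group, an isopropyl group or a primary amine on this carbon would read in this assay remains open, as does whether tert-butyl would give the same drop with an allyl group in place of the prenyl chain.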